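From Pyridine to Pyrimidine on an Imidazoline Scaffold

A few compounds are considered here, and "the series" means these few. Any claim that something is new, unique, unknown or untested is made for them only; others in the source may bear on it.

Of the compounds shown here, two sharing one core have been measured in a functional assay for activation of Alpha-1B adrenergic receptor (Homo sapiens), read by calcium flux; a higher number here means that more compound is needed for the effect, a lower number that less compound is needed. Compound 1 `Cc1ccsc1-c1ccccc1NCC1=NCCN1` carries a 3-methylthiophen-2-yl group, and in this assay compound 1 gives 112 nM. Compound 2 `c1ccc(-c2ccccc2NCC2=NCCN2)nc1` carries pyridin-2-yl in its place, and in this assay compound 2 gives 30.2 nM, the lower of the two numbers; the step of a 3.7-fold lower number from compound 1 to compound 2 (0.57 log units; beyond the scatter) lies beyond the scatter. Compound 3 `c1cnc(-c2ccccc2NCC2=NCCN2)nc1` alters the same position again: pyrimidin-2-yl in place of pyridin-2-yl on an aromatic carbon. For the measured compounds named here, the only measured step bearing on this position is the swap from compound 1 to compound 2, which was modest in size and ran toward a lower number; no measured pair shows pyridin-2-yl giving way to pyrimidin-2-yl, so the direction of the new step is not settled by what is known. Because a 3.7-fold lower number from compound 1 to compound 2 (0.57 log units; beyond the scatter) shows this position accepting a change of ring without a large shift, compound 3 is expected to move little, with an estimated step of a 1.5-fold higher number from compound 2 to compound 3 (0.17 log units; within the scatter). Compound 3 is estimated at 45 nM, most likely between 15 nM and 140 nM.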

Compound 3, half-maximal effective concentration: 77.6 nM
Beside the measured number, compound 3's estimate is 1.7-fold (0.24 log units) below it; measured number inside the range.
By their numbers in this assay, from the lowest: compound 2; then compounds 3 and 1 (each within the scatter of the next).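

In this assay, exchanging one ring carbon for a nitrogen, which turns pyridin-2-yl into pyrimidin-2-yl with the same count of heavy atoms, gives a 2.6-fold higher number from compound 2 to compound 3 (0.41 log units; beyond the scatter), so this position responds to a single atom within a six-membered aromatic ring and not only to a change of ring size or type. The comparison with the thiophene-bearing compound gives a 1.4-fold lower number from compound 1 to compound 3 (0.16 log units; within the scatter), which lies within the scatter, so the six-membered pyrimidin-2-yl and the five-membered 3-methylthiophen-2-yl cannot be told apart here, and pyridin-2-yl alone stands apart, with steps beyond the scatter to both of the others. No accompanying measurement bears on why the added ring nitrogen shifts the number.

The compounds shown leave open where an all-carbon phenyl group would fall at this place, and whether pyridin-3-yl or pyridin-4-yl would keep the number of compound 2 or lose it. They also leave open whether a methyl group on the pyridin-2-yl ring would move the number at all.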